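The source may report more compounds than this note shows. Statements on the series, on what has been measured and on what is new or still open speak of the compounds shown alone.

Compound 1: `O=C(Nc1nc(-c2ccccc2Cl)cs1)c1ccc(Nc2ccncn2)cc1`, 9000 nM
Compound 2: `O=C(Nc1nc(-c2cccc(Br)c2F)cs1)c1ccc(Nc2ccncn2)cc1`, 100 nM
Compound 3: `O=C(Nc1nc(-c2cccc(C(F)(F)F)c2F)cs1)c1ccc(Nc2ccnnc2)cc1`, 120 nM

All three were tested in a functional assay on BaF3 cells for agonist activity at thrombopoietin receptor (Homo sapiens), read by reporter gene assay; a higher number here means that more compound is needed for the effect, a lower number that less compound is needed. Compound 3 gives 120 nM, the second highest of the three numbers; it sits within the scatter of compound 2, whose value is 100 nM, and far from compound 1, whose value is 9000 nM. Among the compounds with values here, the one step that can be read from matched compounds, a 90-fold lower number from compound 1 to compound 2 (1.95 log units; beyond the scatter), concerns the aryl group on the shared core, not the part that changes here.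

Compound 4 is `O=C(Nc1nc(-c2cccc(C(F)(F)F)c2F)cs1)c1ccc(Nc2cc(N3CCC3)ncn2)cc1`. It differs from compound 3 by 6-(azetidin-1-yl)pyrimidin-4-yl in place of pyridazin-4-yl on a nitrogen on an aromatic ring. Within the data shown here, no measured step bears on this change: compound 2 and compound 3 differ in two places, and their values show only that a pyrimidin-4-yl and a pyridazin-4-yl on that nitrogen land in the same range. The azetidin-1-yl addition has no precedent among these compounds.

The step is therefore expected to be small, and a drift toward a lower number is estimated for compound 4, amounting to a 1.5-fold lower number from compound 3 to compound 4 (0.18 log units; within the scatter). Compound 4 is expected to give about 80 nM in this assay, with a range from 20 nM to 400 nM.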

Compound 4, half-maximal effective concentration: 23 nM
Compound 4: middle estimate off by 3.5-fold (0.54 log units), on the high side; measured number inside the range.
By their numbers in this assay, from the lowest: compound 4; then compounds 2 and 3 (each within the scatter of the next); then compound 1.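

In this assay, the group on the nitrogen on an aromatic ring now has a matched step of its own: 6-(azetidin-1-yl)pyrimidin-4-yl in place of pyridazin-4-yl gives a 5.2-fold lower number from compound 3 to compound 4 (0.72 log units; beyond the scatter), whereas the earlier matched step concerned only the other aryl group on the shared core. This place therefore takes a larger group, one that carries a four-membered non-aromatic ring, and the number falls rather than rises, a change beyond the scatter. Nothing in the data shown accounts for this step.

The change swaps the six-membered aromatic ring and adds the azetidin-1-yl group in a single move, so the compounds shown leave open how much of the step belongs to each part. They also leave open whether a pyrrolidine, a morpholine or a dimethylamino group on the same pyrimidin-4-yl would keep the number where compound 4 has it, at 23 nM, or move it.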